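Swapping an amide for a sulfonamide on a pancreatic cell assay

The source may report more compounds than this note shows. Statements on the series, on what has been measured and on what is new or still open speak of the compounds shown alone.

Measured compounds:
compound 1 `CC(C)=CCC1Cc2c(OCCCNC(=O)c3cccs3)cc(=O)n(CCCO)c2CC1(C)C` — 5.6%
compound 2 `CC(C)=CCC/C(C)=C/CC1Cc2c(OCCCNS(=O)(=O)c3ccc([N+](=O)[O-])cc3)cc(=O)n(CCCO)c2CC1(C)C` — 0%

In a functional assay on PANC-1 cells (Homo sapiens) for inhibition, read by MTT assay, with a stated time of 24 h, tested at 10 uM (on this read-out higher numbers stand for more inhibition at the one concentration tested (going by the name of the read-out) and lower numbers for less inhibition), compound 1 gives 5.6%, and compound 2 gives 0%, the lowest of the two numbers; the two values lie within the scatter of each other, so neither stands apart. Compound 3 `CC(C)=CCC/C(C)=C/CC1Cc2c(OCCCNC(=O)c3cccs3)cc(=O)n(CCCO)c2CC1(C)C` has not yet been tested. It differs from compound 2 in one place: (thiophen-2-yl)carbonyl in place of (4-nitrophenyl)sulfonyl on an amine nitrogen. Compound 1 already carries the (thiophen-2-yl)carbonyl and shows only weak inhibition, so no step beyond the scatter is expected in this assay. Compound 3 is estimated at 5% (range 0% to 18%), a change of a number 5 percentage points higher from compound 2 to compound 3 (within the scatter) expected to stay within the scatter.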

Compound 3, a percentage reported as inhibition, at one concentration (the size of the read-out at that concentration, not a potency): 11.5%
The estimate for compound 3 lay 6.5 percentage points below the measured number; measured number inside the range.
By their numbers in this assay, from the lowest: compounds 2, 1 and 3 (each within the scatter of the next, the first and the last beyond it).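

In this assay, (thiophen-2-yl)carbonyl in place of (4-nitrophenyl)sulfonyl on the amine nitrogen gives a number 11.5 percentage points higher from compound 2 to compound 3 (beyond the scatter) as a modest step, the first here to clear the scatter. With 3-methylbut-2-en-1-yl in place of hydrogen on a saturated chain carbon bound to a double-bonded chain carbon, the reading is a number 5.9 percentage points higher from compound 1 to compound 3 (within the scatter) and so shows no clear effect of that addition. Nothing available here explains either step.

The swap alters both the linking group and the ring at once, so a benzoyl or an unsubstituted phenylsulfonyl group on that nitrogen would be needed to tell these two parts apart. Whether any of these compounds would reach strong inhibition remains open.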